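Swapping the furan for chlorophenyl in an amide acrylonitrile

The source may report more compounds than this note shows. Statements on the series, on what has been measured and on what is new or still open speak of the compounds shown alone.

Measured so far:
- compound 1, `N#C/C(=C\c1ccc(Cl)cc1)C(=O)c1ccc[nH]1`: 43000 nM
- compound 2, `N#C/C(=C\c1c[nH]c2ccccc12)C(=O)c1c[nH]c2ccccc12`: 7600 nM
- compound 3, `COc1ccc(CNC(=O)/C(C#N)=C/c2ccc(C)o2)cc1`: > 100000 nM

In a functional assay on NCI-H460 cells (Homo sapiens) for inhibition, read by MTT assay, with a stated time of 72 h (on this read-out lower numbers stand for stronger inhibition of growth and higher numbers for weaker inhibition of growth), compound 3 gives only a limit, > 100000 nM, meaning no number could be read within the tested range; it is the one of the three compounds shown that sits at the limit (the limit of > 100000 nM in this assay, at which 1 of the 3 values shown sits). Compound 4, `COc1ccc(CNC(=O)/C(C#N)=C/c2ccc(Cl)cc2)cc1`, keeps the amide and the nitrile of compound 3 and changes one piece: 4-chlorophenyl in place of 5-methylfuran-2-yl on a double-bonded chain carbon bound to a double-bonded chain carbon. For the measured compounds named here, no measured pair shows the same change, so its effect is unknown. The chlorophenyl-bearing compound 1 gives 43000 nM. For compound 4 the step from the limit an at least 1.1-fold lower number from compound 3 to compound 4 (0.04 log units; that floor lies within the scatter) is expected to be small. Compound 4 is estimated at 90000 nM, with a range from 30000 nM to 300000 nM.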

Compound 4, concentration for 50% growth inhibition: 14000 nM
The estimate for compound 4 lay 6.4-fold (0.81 log units) above the measured number; the whole stated range lies above it.
By their numbers in this assay, from the lowest: compounds 2 and 4 (each within the scatter of the next); then compound 1. At a limit, above all of these: compound 3.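

With the amide and nitrile held fixed, 4-chlorophenyl in place of 5-methylfuran-2-yl gives, in this assay, an at least 7.1-fold lower number from compound 3 to compound 4 (0.85 log units; beyond the scatter). This first pair differing in one place shows that the group on a double-bonded chain carbon bound to a double-bonded chain carbon matters for growth inhibition. The value of compound 3 is a limit, so the step gives only a floor for the size of the change: the limit of > 100000 nM in this assay, at which 1 of the 4 values shown sits.

Going by these compounds, whether the chlorine or the six-membered ring carries the change stays open; a plain phenyl here would separate the two. On these data alone, how an amine or a carboxylic acid on that ring would read is also open.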